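The source may hold more compounds than are shown below. What is called first, only, known or untested is meant among the compounds shown, and "the series" means these compounds.

Compound 1 `COC(c1cc(Cl)c2c(c1Cl)C(=O)N(Cc1c(C)cc(C)[nH]c1=O)CC2)C1CCOC1`: 175 nM; 406 nM; 50 nM; 25 nM (4 entries)
Compound 2 `COC(c1cc(Cl)c2c(c1Cl)C(=O)N(Cc1c(C)cc(C)[nH]c1=O)CC2)C1CCOCC1`: 1150 nM; 19 nM (2 entries)
Compound 3 `Cc1cc(C)c(CN2CCc3c(Cl)cc([C@H](CO)[C@@H]4CCCO4)c(Cl)c3C2=O)c(=O)[nH]1`: 57 nM

These values come from a functional assay on KARPAS-422 cells (Homo sapiens) for antiproliferative activity, read by resazurin assay, with a stated time of 72 h; on this read-out lower numbers stand for stronger inhibition and higher numbers for weaker inhibition. The repeated entries for compound 1 and compound 2 spread widely. Compound 3 has a single number, 57 nM, and two further entries give no single number. That number lies inside the spread of the other two compounds.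

Compound 4 `Cc1cc(C)c(CN2CCc3c(Cl)cc([C@H](C)CO)c(Cl)c3C2=O)c(=O)[nH]1` differs from compound 3 in one place: a group of 4 heavy atoms (3 carbon, 1 oxygen; no ring) in place of a group of 8 heavy atoms (6 carbon, 2 oxygen; one five-membered non-aromatic ring with 1 hetero atom), on an aromatic carbon. The 1-(hydroxymethyl)ethyl group has no ring, whereas all three measured compounds carry a non-aromatic ring in that group. Within the data shown here, no measured pair isolates this change. Starting from compound 3 at 57 nM, a moderate move towards weaker inhibition in this assay, somewhat beyond the scatter, is expected. The expected change is a 4.4-fold higher number from compound 3 to compound 4 (0.64 log units; beyond the scatter). For compound 4 the estimate is 250 nM, with an expected range of 60 nM to 1000 nM.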

Compound 4, half-maximal inhibitory concentration: 186 nM
Compound 4: the middle estimate sits 1.3-fold (0.13 log units) above what was measured, within the range that was stated.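

Among these compounds, compound 4 gives the first step at this position, on the aromatic carbon ortho to a chloro group: in this assay, 1-(hydroxymethyl)ethyl in place of the group carrying the five-membered non-aromatic ring gives a 3.3-fold higher number from compound 3 to compound 4 (0.51 log units; beyond the scatter). The ring is therefore not needed for activity here, although the step is modest. Compound 3 and compound 4 each rest on one number, while repeated entries for a related compound spread widely: the several entries of compound 1 in this assay, 175 nM; 406 nM; 50 nM; 25 nM (4 entries)

The compounds shown leave open whether the hydroxyl is needed. They also leave open how an amine, a carboxylic acid or a longer chain would read at this position in this assay.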